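The compounds below may be only part of what the source reports. "The series", "measured", "known", "first", "only" and "open" are said of these compounds alone.

In an in vitro ADME assay on microsomes from liver (Mus musculus) for pharmacokinetics, read by LC-MS, with a stated time of 10 min, tested at 1 uM (on this read-out higher numbers stand for fast clearance and lower numbers for slow clearance), compound 1 (`CC(C)c1ccc(NC(=O)[C@H]2CN(C)C[C@@H]2c2ccc(/C=C/C(=O)Nc3ccccc3N)cc2)cc1`) gives 54 mL/min/kg and compound 2 (`CN1C[C@H](C(=O)Nc2ccc(Cl)c(Cl)c2)[C@@H](c2ccc(/C=C/C(=O)Nc3ccccc3N)cc2)C1`) gives 36 mL/min/kg. The two numbers lie within the usual scatter of each other, so compound 2 cannot be separated from compound 1 on this read-out. Compound 3 (`CN1C[C@H](C(=O)Nc2cccnc2)[C@@H](c2ccc(/C=C/C(=O)Nc3ccccc3N)cc2)C1`) carries pyridin-3-yl in place of 3,4-dichlorophenyl on an amide-type nitrogen. Within the data shown here, only one measured step bears on this change, the exchange on the same amide-type nitrogen, a 1.5-fold lower number from compound 1 to compound 2 (0.18 log units; within the scatter). That step gives no ground to expect a move beyond the scatter in this assay. Going by these compounds, neither measured compound has a hetero atom in the ring at this place, so the direction remains open. The expected step is a 1.2-fold lower number from compound 2 to compound 3 (0.08 log units; within the scatter), which is no firm change. For compound 3 the estimated clearance is 30 mL/min/kg, with an expected range from 14 mL/min/kg to 60 mL/min/kg.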

Compound 3, clearance: 41 mL/min/kg
Beside the measured number, compound 3's estimate is 1.4-fold (0.14 log units) below it; low and high end bracket the measured number.
By their numbers in this assay, from the lowest: compounds 2, 3 and 1 (each within the scatter of the next).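

In this assay the exchange on the amide-type nitrogen now reaches a ring with a hetero atom: pyridin-3-yl in place of 3,4-dichlorophenyl gives a 1.1-fold higher number from compound 2 to compound 3 (0.06 log units; within the scatter) and pyridin-3-yl in place of 4-isopropylphenyl gives a 1.3-fold lower number from compound 1 to compound 3 (0.12 log units; within the scatter). Both steps stay within the scatter, so a ring nitrogen at this place does not separate compound 3 from either carbon-only aryl compound, and the read-out does not separate any of the three compounds. No further data here offer an explanation for this result.

Going by these compounds, whether a saturated ring such as cyclohexyl, a longer alkyl chain, or an aryl ring carrying a carboxylic acid or an amine on this nitrogen would give a step beyond the scatter remains open. So does the effect of any change elsewhere on the shared core, since all three compounds differ only at this one place.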